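The source may hold more compounds than are shown below. What is called first, only, known or untested is meant among the compounds shown, and "the series" means these compounds.

Compound 1 `COc1ccc(C(=O)c2ccc3c(c2)C=CC(C)(C)O3)c(NC(=O)CBr)c1` gives 3050 nM
Compound 2 `COc1ccc(C(=O)c2ccc3c(c2)C=CC(C)(C)O3)c(NC(=O)CN)c1` gives 580 nM

In a functional assay on HeLa cells (Homo sapiens) for antiproliferative activity, read by MTT assay, with a stated time of 48 h (a higher number here means a weaker inhibitor, a lower number a stronger inhibitor), compound 2 holds the lower of the two numbers at 580 nM and is the stronger inhibitor of the pair. Compound 3 `CNCC(=O)Nc1cc(OC)ccc1C(=O)c1ccc2c(c1)C=CC(C)(C)O2` departs from it by methyl in place of hydrogen on an amine nitrogen and so carries methyl in place of hydrogen on an amine nitrogen. Within the data shown here, the one measured step that bears on this is a 5.3-fold lower number from compound 1 to compound 2 (0.72 log units; beyond the scatter) and it was modest. Among the measured compounds shown here, that step put amino in place of bromo on a saturated chain carbon bound to a carbonyl carbon, but no measurement yet tests methyl on the amine nitrogen. Only a small change is therefore expected in this assay with no direction favoured and none beyond the scatter. The expected step is a 1.2-fold higher number from compound 2 to compound 3 (0.08 log units; within the scatter) on this estimate. For compound 3 the estimated value is 700 nM with 280 nM to 1700 nM as the expected range.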

Compound 3, half-maximal inhibitory concentration: 970 nM
For compound 3 the middle estimate is 1.4-fold (0.14 log units) below the measured one, and the stated range covers the measured number.
By their numbers in this assay, from the lowest: compounds 2 and 3 (each within the scatter of the next); then compound 1.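

In this assay, among these compounds, the amine nitrogen itself is now varied for the first time, and methyl in place of hydrogen there gives a 1.7-fold higher number from compound 2 to compound 3 (0.22 log units; within the scatter), so this nitrogen accepts one methyl without a change that can be told from the scatter. The gain over bromo also survives on this nitrogen, with methylamino in place of bromo giving a 3.1-fold lower number from compound 1 to compound 3 (0.50 log units; beyond the scatter) and showing that it is not confined to the plain amino group. No evidence is available to explain either step.

The compounds shown leave open whether a dimethylamino group, with a second methyl on this nitrogen, or an ethylamino group, with a longer chain, would hold the number. They also leave open how a ring amine such as morpholine or a hydroxyl group in place of the amine would fare on the same chain carbon.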